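The compounds below may be only part of what the source reports. "The series", "measured", "known", "first", "only" and "open" are said of these compounds alone.

Compound 1 `COc1cc(NC(C)CCCNC(=O)NNC(=O)Nc2ccc(Br)cc2)c2ncccc2c1` is the reference here. In a functional assay on MCF7 cells (Homo sapiens) for inhibition, read by MTT assay, with a stated time of 72 h (a higher number here means a weaker inhibitor, a lower number a stronger inhibitor), compound 1 gives 100 nM, the lowest of three numbers measured. Compound 3 `COc1cc(NC(C)CCCNC(=O)NNC(=O)Nc2cccc(C(F)(F)F)c2)c2ncccc2c1` gives 190 nM, and the step of a 1.9-fold higher number from compound 1 to compound 3 (0.28 log units; within the scatter) is small. Compound 2 `COc1cc(NC(C)CCCNC(=O)Nc2ccc(O)cc2)c2ncccc2c1` gives 5200 nM, a large step of a 52-fold higher number from compound 1 to compound 2 (1.72 log units; beyond the scatter), though that change also shortens the linker. Compound 4 `COc1cc(NC(C)CCCNC(=O)NNC(=O)Nc2ccc(O)cc2)c2ncccc2c1` differs from compound 1 by hydroxy in place of bromo on an aromatic carbon. Among the compounds with values here, only the step to compound 2 bears on this hydroxy group, and it is confounded, so a moderate weakening is expected for compound 4, smaller than a 52-fold higher number from compound 1 to compound 2 (1.72 log units; beyond the scatter). The expected step is a 4.0-fold higher number from compound 1 to compound 4 (0.60 log units; beyond the scatter). Compound 4 is therefore estimated at 400 nM, between 120 nM and 1500 nM.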

Compound 4, half-maximal inhibitory concentration: 2600 nM
The estimate for compound 4 lay 6.5-fold (0.81 log units) below the measured number; measured number outside the range, above it.
By their numbers in this assay, from the lowest: compounds 1 and 3 (each within the scatter of the next); then compounds 4 and 2 (each within the scatter of the next).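

Changing a single atom on this aromatic carbon, from bromo to hydroxy, is enough for a large loss: a 26-fold higher number from compound 1 to compound 4 (1.41 log units; beyond the scatter). The 3-(trifluoromethyl)phenyl compound shows a similar gap, a 14-fold higher number from compound 3 to compound 4 (1.14 log units; beyond the scatter), whereas the linker difference between two 4-hydroxyphenyl compounds gives only a 2.0-fold lower number from compound 2 to compound 4 (0.30 log units; within the scatter), so the earlier large step to compound 2 follows the hydroxy group rather than the linker. No measurement shown here explains why hydroxy is so much worse than bromo.

From the compounds shown here alone, whether a methoxy group or a chloro group on this carbon would stay close to compound 1 or to compound 4 remains open. So does whether an amine there would behave like the hydroxy group.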